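This account rests on a few compounds, and the source may have more. Where it says the series, first, only, none or still open, it means among the compounds named here.

Working notes on the series. Compound 1 `COc1ncnc2c1c(-c1ccsc1)cn2[C@@H]1O[C@H](CO)[C@@H](O)[C@H]1O` gives 120 nM in a functional assay on HCT-116 cells (Homo sapiens), read by MTT assay, with a stated time of 72 h; a higher number here means a weaker inhibitor, a lower number a stronger inhibitor. Compound 2 `CN(C)c1ncnc2c1c(-c1ccsc1)cn2[C@@H]1O[C@H](CO)[C@@H](O)[C@H]1O` reaches only a limit of this assay, > 20000 nM. Compound 3 `COc1ncnc2c1c(-c1ccoc1)cn2[C@@H]1O[C@H](CO)[C@@H](O)[C@H]1O` gives 110 nM in this assay. The change dimethylamino in place of methoxy on an aromatic carbon made an at least 160-fold higher number from compound 1 to compound 2 (2.22 log units; beyond the scatter), a step that ends at a limit (the limit of > 20000 nM in this assay, at which 1 of the 3 values shown sits). The change furan-3-yl in place of thiophen-3-yl on an aromatic carbon made a 1.1-fold lower number from compound 1 to compound 3 (0.04 log units; within the scatter). Compound 4 `CN(C)c1ncnc2c1c(-c1ccoc1)cn2[C@@H]1O[C@H](CO)[C@@H](O)[C@H]1O` is not yet measured; it differs from compound 3 by dimethylamino in place of methoxy on an aromatic carbon, the same change as from compound 1 to compound 2, at the same place. The expected step of a 230-fold higher number from compound 3 to compound 4 (2.36 log units; beyond the scatter) rests on an at least 160-fold higher number from compound 1 to compound 2 (2.22 log units; beyond the scatter), read against compound 1 and compound 3 sitting within the scatter of each other. Compound 4 is therefore expected to give about 25000 nM in this assay, most likely reported only as a limit, with an expected range from 8000 nM to 80000 nM.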

Compound 4, half-maximal inhibitory concentration: > 20000 nM
Compound 4: no number, only a limit; the forecaster's own chance of this, stated with the estimate: 85%; the middle value lies beyond the limit too.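

In this assay, dimethylamino in place of methoxy on an aromatic carbon again ends at a limit, with an at least 180-fold higher number from compound 3 to compound 4 (2.25 log units; beyond the scatter), so the large step seen with the thiophen-3-yl group recurs with the furan-3-yl group. The change therefore carries across these two cores in direction, but only a minimum size is shown for each, not whether the true sizes match: the same change on two cores in this assay, an at least 160-fold higher number (2.22 log units; beyond the scatter) from compound 1 to compound 2 and an at least 180-fold higher number (2.25 log units; beyond the scatter) from compound 3 to compound 4; the limit leaves it open whether they differ. The step between the two dimethylamino compounds cannot be read, as both values are limits: the limit of > 20000 nM in this assay, at which 2 of the 4 values shown sit.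

Open, as far as these compounds go, is how other groups on the same aromatic carbon behave, such as an unsubstituted amine, a methylamino group or a longer chain such as ethoxy. Also open, from the compounds shown here alone, is whether any of them stays close to compound 3 at 110 nM.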